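One Nitrogen in Place of Five Atoms: Expecting Compound 4

The source may report more compounds than this note shows. Statements on the series, on what has been measured and on what is new or still open speak of the compounds shown alone.

Compound 2 `CN(C)/C=N/c1c(C=O)c(-c2ccccc2)nn1-c1ccccc1` carries a formyl group and a phenyl group on its five-membered aromatic ring with 2 nitrogen. Among the compounds with values here, in a functional assay on NPC-TW01 cells (Homo sapiens) for inhibition, read by MTT assay, with a stated time of 72 h (on this read-out higher numbers stand for weaker inhibition of growth and lower numbers for stronger inhibition of growth), compound 2 gives 9300 nM, the only plain number among the three values shown. Compound 1 `Cc1ccc(-c2cc(N)n(-c3cccc(Cl)c3)n2)cc1` and compound 3 `Cc1ccc(-c2cc(/N=C/N(C)C)n(-c3cccc(Cl)c3)n2)cc1` share a different core, bearing a 3-chlorophenyl group and a 4-methylphenyl group; how that core differs from the core of compound 2 is not broken down here. Compound 1 reaches only a limit of this assay, > 100000 nM. Compound 3 likewise reaches only a limit, > 100000 nM. The change from compound 3 to compound 1, (one nitrogen atom in place of a group of 5 heavy atoms (3 carbon, 2 nitrogen; no ring), on an aromatic carbon), gives a step that the two limits leave unreadable from compound 3 to compound 1, because of the limit of > 100000 nM in this assay, at which 2 of the 3 values shown sit.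

Compound 4 `Nc1c(C=O)c(-c2ccccc2)nn1-c1ccccc1` follows from compound 2 by the same kind of change, (one nitrogen atom in place of a group of 5 heavy atoms (3 carbon, 2 nitrogen; no ring), on an aromatic carbon). The surroundings differ: in compound 2 the place sits next to the ring atom that bears a formyl group and next to the ring atom that bears a phenyl group, whereas in compound 3 it sits next to the ring atom that bears a 3-chlorophenyl group and two ring bonds from the ring atom that bears a 4-methylphenyl group. The measured pair gives no readable size, so the expectation for compound 4 rests only on compound 2 and its value 9300 nM: the step is estimated as a 1.6-fold higher number from compound 2 to compound 4 (0.21 log units; within the scatter). Compound 4 is therefore expected to give about 15000 nM in this assay, estimated between 4000 nM and 60000 nM.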

Compound 4, concentration for 50% growth inhibition: > 100000 nM
Compound 4 was reported as a limit; the forecaster's own chance of this, stated with the estimate: 25%; middle value at least 6.6-fold (0.82 log units) away from the limit.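

In this assay, putting amino in place of the group of 5 heavy atoms on the core of compound 2 gives an at least 10-fold higher number from compound 2 to compound 4 (1.03 log units; beyond the scatter), so on this core the change goes with weaker inhibition of growth, by a margin beyond the usual scatter. Compound 4 gives > 100000 nM, which is a limit of the assay and not a number. This is the only readable instance of the change, and it does not show that the change behaves alike on both cores, since the step on the core of compound 3 cannot be read, and no size can be set beside the new one, because the values stand at the assay's limit: the limit of > 100000 nM in this assay, at which 3 of the 4 values shown sit.

Within the data shown here, what remains open is whether any other group on that aromatic carbon, such as a methylamino group, an acetamide or a longer amine chain, would match or better compound 2 at 9300 nM, the only plain number in this set. Also open, from the compounds shown here alone, is how much the formyl group contributes on this core, which a nitrile or a carboxylic acid at the same ring atom could test, and whether the same change could be read at all on a core that starts from a plain number.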